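A few compounds are considered here, and "the series" means these few. Any claim that something is new, unique, unknown or untested is made for them only; others in the source may bear on it.

Within the data shown here, compound 2 `COC(=O)c1cccc(CSc2nc(N)c(C#N)c(-c3ccc(OCC4CC4)cc3)c2C#N)c1` stands lowest of the two compounds measured so far: in an assay on CHO cells for displacement of a labelled ligand from adenosine receptor A3 (Homo sapiens), read by scintillation counting, with a stated time of 120 min, tested at 1 uM (a higher number here means more inhibition at the concentration tested (going by the name of the read-out), a lower number less inhibition), compound 2 gives 4%, while compound 1 `CCOc1ccc(-c2c(C#N)c(N)nc(SCc3ccn[nH]3)c2C#N)cc1` gives 18%, a gap beyond the usual scatter. Compound 3 `N#Cc1c(N)nc(SCc2ncn[nH]2)c(C#N)c1-c1ccc(OCC2CC2)cc1` has not yet been measured. It differs from compound 2 in a single place: 1H-1,2,4-triazol-5-yl in place of 3-(methoxycarbonyl)phenyl on a saturated chain carbon bound to a sulfur. Compound 3 thus carries a small azole on that chain, as compound 1 with its 18% does, so an upward but modest step is expected, a number 8 percentage points higher from compound 2 to compound 3 (within the scatter). Compound 3 is therefore estimated to give about 12%, most likely between 0% and 28%.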

Compound 3, a percentage reported as inhibition, at one concentration (the size of the read-out at that concentration, not a potency): 1%
For compound 3 the middle estimate is 11 percentage points above the measured one; the measured number falls inside the stated range.
By their numbers in this assay, from the lowest: compounds 3 and 2 (each within the scatter of the next); then compound 1.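

In this assay, putting 1H-1,2,4-triazol-5-yl in place of 3-(methoxycarbonyl)phenyl on a saturated chain carbon bound to a sulfur gives a number 3 percentage points lower from compound 2 to compound 3 (within the scatter). At this position, then, two very different rings, one a six-membered carbon ring and the other a five-membered ring with a hydrogen-bond donor, cannot be told apart at this single concentration.

Whether a carboxylic acid or a simple amine on that chain carbon would give a clearly different number remains open, and no measured evidence here accounts for the result.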